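Aminomethyl substitution on the saturated ring: compound 2 to 3

A few compounds are considered here, and "the series" means these few. Any claim that something is new, unique, unknown or untested is made for them only; others in the source may bear on it.

Of the compounds shown here, two have numbers so far. Compound 1 `CN(C)CC1CCC/C(=C\c2ccc(OC(=O)/C=C/c3ccc(Br)cc3)cc2)C1=O` carries the (dimethylamino)methyl group on its saturated ring; in a functional assay on MOLT-4 cells (Homo sapiens) (on this read-out higher numbers stand for weaker inhibition and lower numbers for stronger inhibition), compound 1 gives 3060 nM. Compound 2 `O=C1CCCC/C1=C\c1ccc(OC(=O)c2ccc(Cl)cc2)cc1` lacks that group and carries a chlorinated benzoate ester; in this assay compound 2 gives 38000 nM, the highest of the two numbers and well beyond the scatter from compound 1. Among the compounds with values here, since compound 1 and compound 2 differ in both the ester part and the saturated ring, no single-point step can be drawn between them.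

Compound 3 `CN(C)CC1CCC/C(=C\c2ccc(OC(=O)c3ccc(Cl)cc3)cc2)C1=O` keeps the ester of compound 2 and changes only the saturated ring: (dimethylamino)methyl in place of hydrogen on a saturated ring carbon. Within the data shown here, for this change no measured step exists. Among the measured compounds shown here, compound 1, the only compound bearing the (dimethylamino)methyl group, stands at 3060 nM, so a move toward lower numbers is expected, though of uncertain size. The expected step from compound 2 to compound 3 is a 5.4-fold lower number from compound 2 to compound 3 (0.73 log units; beyond the scatter). Compound 3 is estimated at 7000 nM, within a range of 1500 nM to 30000 nM.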

Compound 3, half-maximal inhibitory concentration: 5110 nM
For compound 3 the middle estimate is 1.4-fold (0.14 log units) above the measured one; low and high end bracket the measured number.
By their numbers in this assay, from the lowest: compounds 1 and 3 (each within the scatter of the next); then compound 2.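

In this assay the swap of hydrogen for (dimethylamino)methyl on a saturated ring carbon gives a 7.4-fold lower number from compound 2 to compound 3 (0.87 log units; beyond the scatter) with the ester held constant, so this change now has a single-place reading that lies beyond the scatter. With the (dimethylamino)methyl group in place, 4-chlorophenyl in place of 2-(4-bromophenyl)ethenyl on a carbonyl carbon gives a 1.7-fold higher number from compound 1 to compound 3 (0.22 log units; within the scatter) and so stays within the scatter; at this level of inhibition the two esters cannot be told apart in this assay. No measurement at hand speaks to the cause of either step.

Going by these compounds, the step at the saturated ring carbon rests on a single pair carrying the chlorinated benzoate ester, so whether it holds with the 2-(4-bromophenyl)ethenyl ester remains open. Also open, on these data alone, is how this ring carbon would read with other groups in the place of (dimethylamino)methyl, such as (diethylamino)methyl, a morpholine on the same methylene, a longer chain ending in the dimethylamino group, or a carboxylic acid.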